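Swapping the ring on the amide nitrogen of compound 1

The source may report more compounds than this note shows. Statements on the series, on what has been measured and on what is new or still open speak of the compounds shown alone.

Compound 1, `Cc1nc(Cc2ccc(Cl)cc2)sc1C1SCC(=O)N1c1ccc(F)c(Cl)c1`: 45.1%
Compound 2, `COc1ccc(N2C(=O)CSC2c2sc(-c3ccccc3)nc2C)cc1`: 48.2%
Compound 3, `Cc1nc(-c2ccc(Cl)cc2)sc1C1SCC(=O)N1c1ccc(F)cc1`: 63.9%

In a functional assay on the whole organism (strain Wistar albino) for inhibition, with Rattus norvegicus as the target, read by paw edema, with stated times of 1 h and 2 h, at a dose of 40 mg/kg by the oral route (on this read-out lower numbers stand for less inhibition and higher numbers for more inhibition at the one dose given (going by the name of the read-out)), compound 1 gives 45.1%, the lowest of the three numbers. Compound 2 gives 48.2%, which lies within the scatter of compound 1, so the two cannot be told apart. Compound 3 gives 63.9%, beyond the scatter above compound 1.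

Compound 4, `Cc1nc(Cc2ccc(Cl)cc2)sc1C1SCC(=O)N1c1ccc(Cl)cc1`, has not yet been measured. It differs from compound 1 in one place: 4-chlorophenyl in place of 3-chloro-4-fluorophenyl on an amide-type nitrogen in a ring. Within the data shown here, no measured pair shows this change, so its effect is unknown. The step is expected to be small, in either direction, or none beyond the scatter. Compound 4 is expected to give 48%, between 36% and 60%. The expected step is a number 2.9 percentage points higher from compound 1 to compound 4 (within the scatter), within the scatter.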

Compound 4, a percentage reported as inhibition, in the whole organism at one dose (the size of the read-out at that dose, not a potency): 40.1%
Beside the measured number, compound 4's estimate is 7.9 percentage points above it; the range from low to high includes it.
By their numbers in this assay, from the lowest: compounds 4, 1 and 2 (each within the scatter of the next); then compound 3.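

In this assay this first direct pair at the amide-type nitrogen gives a number 5 percentage points lower from compound 1 to compound 4 (within the scatter), so 4-chlorophenyl and 3-chloro-4-fluorophenyl cannot be told apart here. At this one dose, then, the read-out does not separate these two chlorinated phenyl rings on this nitrogen. No supporting data explain this result. Still open, on these data alone, is whether a pyridine ring or a short alkyl chain such as ethyl on this nitrogen would give a step beyond the scatter. Also open, as far as these compounds go, is whether an unsubstituted phenyl ring would do so.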